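A few compounds are considered here, and "the series" means these few. Any claim that something is new, unique, unknown or untested is made for them only; others in the source may bear on it.

In an in vitro ADME assay on microsomes from liver (Homo sapiens) for metabolic stability (on this read-out higher numbers stand for fast clearance and lower numbers for slow clearance), compound 1 `CC[C@H](C)[C@@H]1C(=O)N[C@H](C2Cc3ccccc3C2)C(=O)N1[C@@H](C(=O)N1CCOCC1)c1cnc(C)cc1C` gives 1 mL.min-1.g-1, the lower of the two numbers available, while compound 2 `CCC(CC)[C@@H]1C(=O)N[C@H](C2Cc3ccccc3C2)C(=O)N1[C@@H](C(=O)N1CCOCC1)c1ccc(C)nc1` gives 12 mL.min-1.g-1, a gap beyond the scatter, although these two compounds differ in more than one place. Compound 3 `CC[C@H](C)[C@@H]1C(=O)N[C@H](C2Cc3ccccc3C2)C(=O)N1[C@@H](C(=O)N(C)C)c1cnc(C)cc1C` keeps the core of compound 1 but carries dimethylamino in place of morpholin-4-yl on a carbonyl carbon. Among the measured compounds shown here, no measured pair shows this change alone, so the expectation starts from compound 1 at 1 mL.min-1.g-1. A small rise in this assay, hardly beyond the scatter, is expected, with an estimated step of a 2.0-fold higher number from compound 1 to compound 3 (0.30 log units; within the scatter). For compound 3 the expected value is 2 mL.min-1.g-1, with an estimated range of 1 mL.min-1.g-1 to 6 mL.min-1.g-1.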

Compound 3, intrinsic clearance in microsomes: 9 mL.min-1.g-1
Estimate against measurement, compound 3: 4.5-fold (0.65 log units) below; measured number above the stated range.
By their numbers in this assay, from the lowest: compound 1; then compounds 3 and 2 (each within the scatter of the next).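

In this assay, dimethylamino in place of morpholin-4-yl on a carbonyl carbon gives a 9.0-fold higher number from compound 1 to compound 3 (0.95 log units; beyond the scatter). Among the compounds shown here, this is the first view of this position alone, and it shows that the group on this carbonyl carbon bears on the read-out while the rest of compound 1 stays unchanged. Nothing available explains the step.

The compounds shown leave open whether the ring or its oxygen matters more, a question that piperidin-1-yl on the same carbonyl carbon would address. As far as these compounds go, whether the change carries over to the core of compound 2 also stays open.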